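The compounds below may be only part of what the source reports. "The series", "measured", "known", "first", "only" and "open" are said of these compounds alone.

Compound 3 (`CC1CCN(C2CCN(S(=O)(=O)c3ccc(C#N)cc3)CC2)CC1`) is one of three close analogues that share one core and differ only in the aryl group on the sulfonyl sulfur. In an ADME assay on HCT-116 cells (Homo sapiens) for cytotoxicity, read by CellTiter-Glo, with a stated time of 72 h (a higher number here means a weaker inhibitor, a lower number a stronger inhibitor), compound 3 gives > 5000 nM, which is a limit of the assay and not a measured number. Compound 1 (`CCc1ccc(S(=O)(=O)N2CCC(N3CCC(C)CC3)CC2)cc1`) gives > 5000 nM in this assay, again only a limit. Compound 2 (`Cc1ccc(-c2cccc(S(=O)(=O)N3CCC(N4CCC(C)CC4)CC3)c2)cc1`) gives > 5000 nM, a limit as well. Within the data shown here, the one single-point comparison available, a step that the two limits leave unreadable from compound 1 to compound 3, is therefore unreadable in size, and the only pattern the data offer is the limit of > 5000 nM in this assay, at which 3 of the 3 values shown sit.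

The next compound, compound 4 (`CC1CCN(C2CCN(S(=O)(=O)c3cccc(N)c3)CC2)CC1`), differs from compound 3 in one place: 3-aminophenyl in place of 4-cyanophenyl on a sulfonyl sulfur. Among the measured compounds shown here, no measured step bears directly on an amino group at this position, and the cyano-for-ethyl step gave no readable size. For the measured compounds named here, because every value so far sits at the same limit (the limit of > 5000 nM in this assay, at which 3 of the 3 values shown sit), the expectation for compound 4 is simply that it, too, will fall at or beyond that limit, with no step beyond the scatter to be read; the expected step that the limit leaves unreadable from compound 3 to compound 4 is accordingly flat. Compound 4 is thus estimated at 10000 nM in this assay, within a range from 5000 nM to 50000 nM, and most likely to be reported only as a limit.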

Compound 4, half-maximal inhibitory concentration: > 5000 nM
Compound 4: a limit, no number (the forecaster's own chance of this, stated with the estimate: 85%); the middle value lies beyond the limit too.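

In this assay compound 4 gives > 5000 nM, which is a limit of the assay and not a number. Its steps to compound 1, compound 2 and compound 3 therefore cannot be read. The compounds shown leave open how far each lies beyond that limit and whether any aryl group on the sulfonyl sulfur gives a measurable value in this assay.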